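The source may hold more compounds than are shown below. What is called first, only, known or untested is meant among the compounds shown, and "the series" means these compounds.

Working notes on the series. Two compounds have numbers in a functional assay on A549 cells (Homo sapiens) for inhibition; on this read-out lower numbers stand for stronger inhibition and higher numbers for weaker inhibition. Compound 1 `CC(C)c1ccc(N2C(=O)C=CC2OCC(F)(F)F)cc1` carries an isopropyl group on its aryl ring and a trifluoroethyl ether on the shared core; in this assay compound 1 gives 9570 nM, the highest of the two numbers. Going by the values given here, compound 2 `O=C1C=CC(OC(C(F)(F)F)C(F)(F)F)N1c1ccc(Cl)cc1` carries a chloro group at the same aryl position with a hexafluoroisopropyl ether and gives 4300 nM; the gap between these two lies beyond the scatter, but the compounds differ in two places, so no single step is isolated. Compound 3 `O=C1C=CC(OCC(F)(F)F)N1c1ccc(Br)cc1` is the next point: bromo in place of isopropyl on an aromatic carbon. Compound 2 shows that a halogen at this place sits with a lower number, so a modest downward step is expected, a 1.7-fold lower number from compound 1 to compound 3 (0.24 log units; within the scatter), though the ether also differs between those two. Compound 3 is estimated at 5500 nM, with a range from 2000 nM to 15000 nM.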

Compound 3, half-maximal inhibitory concentration: 6960 nM
Compound 3: the middle estimate sits 1.3-fold (0.10 log units) below what was measured; measured number inside the range.
By their numbers in this assay, from the lowest: compounds 2, 3 and 1 (each within the scatter of the next, the first and the last beyond it).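

Going by these compounds alone, with the trifluoroethyl ether held constant, bromo in place of isopropyl on an aromatic carbon gives a 1.4-fold lower number from compound 1 to compound 3 (0.14 log units; within the scatter) and isolates a single change at this position for the first time. In this assay, replacing the isopropyl group's 3 carbon atoms with 1 bromine atom therefore leaves the number within the scatter, so this change does not separate the two groups. No supporting data bear on why these two groups read alike.

On these data alone, it remains open whether an amine, a methoxy group or a carboxylic acid on this aromatic carbon would move the number beyond the scatter. As far as these compounds go, the contribution of the hexafluoroisopropyl ether also remains open, since the trifluoroethyl and hexafluoroisopropyl ethers are not compared on an otherwise identical aryl ring.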